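A Methoxy Added to Compound 1

The source may report more compounds than this note shows. Statements on the series, on what has been measured and on what is new or still open speak of the compounds shown alone.

In a functional assay on MIA PaCa-2 cells (Homo sapiens) for antiproliferative activity, read by sulforhodamine B assay, with a stated time of 48 h (a lower number here means a stronger inhibitor, a higher number a weaker inhibitor), compound 1 `COc1cc(OC)c2sc(-c3ccc(N/C=C\C(=O)c4ccc(OC)c([N+](=O)[O-])c4)cc3)nc2c1` gives 2900 nM and compound 2 `COc1cc(OC)c2sc(-c3ccc(N/C=C\C(=O)c4ccc(OC)c(F)c4)cc3)nc2c1` gives 4300 nM, so these two values lie within the scatter of each other. For the measured compounds named here, the only measured step, a 1.5-fold higher number from compound 1 to compound 2 (0.17 log units; within the scatter), puts fluoro in place of nitro and stays small. Compound 3 `COc1cc(OC)c2sc(-c3ccc(N/C=C\C(=O)c4cc(OC)c(OC)c([N+](=O)[O-])c4)cc3)nc2c1` keeps the nitro of compound 1 and differs by methoxy in place of hydrogen on an aromatic carbon. Going by the values given here, no measured step tests this change, so nothing beyond the scatter is expected. The expected step is a 1.1-fold lower number from compound 1 to compound 3 (0.03 log units; within the scatter). For compound 3 the estimated value is 2700 nM, with an expected range from 900 nM to 8000 nM.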

Compound 3, half-maximal inhibitory concentration: 12700 nM
For compound 3 the middle estimate is 4.7-fold (0.67 log units) below the measured one, and the stated range ends below it.
By their numbers in this assay, from the lowest: compounds 1 and 2 (each within the scatter of the next); then compound 3.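

Methoxy in place of hydrogen on this aromatic carbon, ortho to a methoxy group and meta to a nitro group, gives a 4.4-fold higher number from compound 1 to compound 3 (0.64 log units; beyond the scatter) in this assay. For the compounds shown here, this is the first change to go beyond the scatter, so a hydrogen at this position cannot be swapped for methoxy without a cost in this assay. No available measurement explains why. On these data alone, whether a hydroxyl, an amine or a longer chain such as ethoxy at this position would cost as much remains open. So does whether the same methoxy would weaken compound 2, which carries fluoro in place of nitro.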